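The source may hold more compounds than are shown below. What is called first, only, known or untested is meant among the compounds shown, and "the series" means these compounds.

Measured so far in an in vitro ADME assay on microsomes from liver (Mus musculus) for pharmacokinetics, read by LC-MS, with a stated time of 10 min, tested at 1 uM; on this read-out lower numbers stand for slow clearance and higher numbers for fast clearance:
compound 1, `Cc1ccc(NC(=O)[C@H]2CN(C)C[C@@H]2c2ccc(/C=C/C(=O)Nc3ccccc3N)cc2)cc1`: 62 mL/min/kg
compound 2, `CN1C[C@H](C(=O)Nc2ccc(C(F)(F)F)cc2)[C@@H](c2ccc(/C=C/C(=O)Nc3ccccc3N)cc2)C1`: 23 mL/min/kg
compound 3, `CN1C[C@H](C(=O)Nc2ccccc2F)[C@@H](c2ccc(/C=C/C(=O)Nc3ccccc3N)cc2)C1`: 67 mL/min/kg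

Compound 3 has the highest of the three numbers; its value and that of compound 1 lie within the scatter of each other, while a 2.9-fold higher number from compound 2 to compound 3 (0.46 log units; beyond the scatter) is beyond it. Compound 4, `CC(C)NC(=O)[C@H]1CN(C)C[C@@H]1c1ccc(/C=C/C(=O)Nc2ccccc2N)cc1`, is next: isopropyl in place of 2-fluorophenyl on an amide-type nitrogen. Two measured steps alter the group on the same amide-type nitrogen, a 1.1-fold higher number from compound 1 to compound 3 (0.03 log units; within the scatter) and a 2.9-fold higher number from compound 2 to compound 3 (0.46 log units; beyond the scatter), but neither replaces an aromatic group by a chain, so their bearing is indirect; the known swaps give at most a modest shift. A shift of that size in either direction is possible, most likely none beyond the scatter. Compound 4 is therefore estimated at 50 mL/min/kg, range 20 mL/min/kg to 110 mL/min/kg, with a 1.3-fold lower number from compound 3 to compound 4 (0.13 log units; within the scatter) the expected step.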

Compound 4, clearance: 12 mL/min/kg
The estimate for compound 4 lay 4.2-fold (0.62 log units) above the measured number, outside the stated range (below it).
By their numbers in this assay, from the lowest: compounds 4 and 2 (each within the scatter of the next); then compounds 1 and 3 (each within the scatter of the next).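

In this assay, isopropyl is the only chain among the groups shown on this amide-type nitrogen, and an aromatic group there is not needed for a low clearance number: a 5.6-fold lower number from compound 3 to compound 4 (0.75 log units; beyond the scatter) and a 5.2-fold lower number from compound 1 to compound 4 (0.71 log units; beyond the scatter) are both beyond the scatter. Against 4-(trifluoromethyl)phenyl, however, a 1.9-fold lower number from compound 2 to compound 4 (0.28 log units; within the scatter) stays within it, so the change from an aromatic group to isopropyl does not separate all the aromatic compounds from compound 4. Nothing available explains these steps.

The compounds shown leave open whether a straight propyl chain, a cyclohexyl ring or a chain carrying an amine on the same nitrogen would give a number like that of compound 4.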